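The source may report more compounds than this note shows. Statements on the series, on what has been measured and on what is new or still open speak of the compounds shown alone.

Compound 1 `C#Cc1cc(C)oc(=O)c1`: 3100 nM
Compound 2 `CCCCC#Cc1cc(C)oc(=O)c1`: 7000 nM

In a functional assay on A2780 cells (Homo sapiens) for inhibition (a lower number here means a stronger inhibitor, a higher number a weaker inhibitor), compound 2 holds the higher of these two numbers, the weaker of the pair, and the step of a 2.3-fold higher number from compound 1 to compound 2 (0.35 log units; beyond the scatter) lies beyond the scatter. Compound 3 `CCCCCC#Cc1cc(C)oc(=O)c1` differs from compound 2 by methyl in place of hydrogen on a saturated chain carbon, four bonds along the chain from a triple-bonded carbon, so the butyl chain of compound 2 grows to pentyl. Among the compounds with values here, only the step of a 2.3-fold higher number from compound 1 to compound 2 (0.35 log units; beyond the scatter) bears on this, and it moved toward weaker inhibition when a chain was introduced; lengthening that chain by one carbon is a smaller change, so a small further rise, or none beyond the scatter, is expected. Compound 3 is therefore estimated at 9000 nM, within 4000 nM to 20000 nM, a step of a 1.3-fold higher number from compound 2 to compound 3 (0.11 log units; within the scatter).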

Compound 3, half-maximal inhibitory concentration: 2900 nM
Compound 3: the middle estimate sits 3.1-fold (0.49 log units) above what was measured, and the stated range ends above it.
By their numbers in this assay, from the lowest: compounds 3 and 1 (each within the scatter of the next); then compound 2.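

In this assay the effect of chain length at this position does not run in one direction: methyl in place of hydrogen on a saturated chain carbon, four bonds along the chain from a triple-bonded carbon, gives a 2.4-fold lower number from compound 2 to compound 3 (0.38 log units; beyond the scatter), so butyl's loss does not continue with pentyl. The pentyl chain gives a 1.1-fold lower number from compound 1 to compound 3 (0.03 log units; within the scatter), so this longer chain costs nothing measurable. Nothing available explains why one added carbon reverses the earlier rise. As far as these compounds go, whether a hexyl chain follows pentyl or butyl remains open, as does the effect of an amine or a carboxylic acid at the chain end.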